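A few compounds are considered here, and "the series" means these few. Any claim that something is new, unique, unknown or untested is made for them only; others in the source may bear on it.

Series notes, cytotoxicity. The read-out is a functional assay on MCF7 cells (Homo sapiens) for cytotoxicity, read by MTT assay, with a stated time of 48 h; a lower number here means a stronger inhibitor, a higher number a weaker inhibitor. Of the compounds shown here, two have numbers so far. Compound 1 `Cc1ccccc1OCC(=O)Nc1nc(-c2ccc(Br)cc2)cs1` gives 40100 nM in this assay. Compound 2 `Cc1ccccc1OCC(=O)Nc1nc(-c2ccc(Cl)cc2)cs1` gives 62200 nM in this assay. Among the compounds with values here, the one measured step, a 1.6-fold higher number from compound 1 to compound 2 (0.19 log units; within the scatter), lies within the scatter, so the two values are taken as equal for working purposes. Compound 2 stands highest of the two numbers, with compound 1 its nearest neighbour and within the scatter of it.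

Compound 3 `Cc1ccc(OCC(=O)Nc2nc(-c3ccc(Cl)cc3)cs2)cc1` differs from compound 2 by 4-methylphenyl in place of 2-methylphenyl on an oxygen on a saturated carbon. Within the data shown here, no measured step touches this part of the molecule: the only step at hand, a 1.6-fold higher number from compound 1 to compound 2 (0.19 log units; within the scatter), concerns the other aromatic ring and is itself within the scatter. The two compounds measured give no direction for a move of the methyl on the phenoxy ring. The expectation is therefore a step of no size beyond the scatter, a 1.0-fold lower number from compound 2 to compound 3 (0.02 log units; within the scatter), with a wide range to cover the lack of any bearing step. Compound 3 is estimated at 60000 nM in this assay, between 20000 nM and 180000 nM.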

Compound 3, half-maximal inhibitory concentration: 48700 nM
Compound 3: the middle estimate sits 1.2-fold (0.09 log units) above what was measured; the measured number falls inside the stated range.
By their numbers in this assay, from the lowest: compounds 1, 3 and 2 (each within the scatter of the next).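

Placing the methyl as 4-methylphenyl rather than 2-methylphenyl, on an oxygen on a saturated carbon, gives a 1.3-fold lower number from compound 2 to compound 3 (0.11 log units; within the scatter) in this assay, the first measured step at this part of the molecule. With the chloro-bearing side held constant, the two methylphenyl isomers are therefore taken as equal for working purposes, and these two placements of the methyl do not separate the compounds in this read-out. Nothing at hand bears on why the two isomers read alike.

Only these two placements of a single methyl have been seen at this position, so a plain phenyl, a methoxy, an amine or a carboxylic acid on the phenoxy ring remains an open question, as does a longer chain in place of the saturated carbon that carries the oxygen. Since every measured step so far lies within the scatter, neither the halogen side nor the phenoxy side has yet shown a change of any size, and whether either part of the molecule can shift the cytotoxicity number at all is still unanswered.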